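This account rests on a few compounds, and the source may have more. Where it says the series, first, only, none or still open, it means among the compounds named here.

Compound 1 `Cc1ccc(S/C(=C/c2c[nH]c3ccc(Cl)cc23)C(=O)c2ccc(Br)cc2)cc1`: 1000 nM
Compound 2 `COc1ccc(/C=C(\C(=O)c2ccc(Br)cc2)S(=O)(=O)c2ccc(C)cc2)cc1`: 1000 nM
Compound 3 `Cc1ccc(S(=O)(=O)/C(=C/c2ccc(N(C)C)cc2)C(=O)c2ccc(Br)cc2)cc1`: 50000 nM

In a functional assay on DU-145 cells (Homo sapiens) for inhibition, read by trypan blue exclusion, with a stated time of 96 h (on this read-out lower numbers stand for stronger inhibition of growth and higher numbers for weaker inhibition of growth), compound 3 gives 50000 nM, the highest number of the three. Compound 4 `Cc1ccc(S(=O)(=O)/C(=C/c2c[nH]c3ccc(Cl)cc23)C(=O)c2ccc(Br)cc2)cc1` has 5-chloro-1H-indol-3-yl in place of the 4-(dimethylamino)phenyl of compound 3: 5-chloro-1H-indol-3-yl in place of 4-(dimethylamino)phenyl on a double-bonded chain carbon bound to a double-bonded chain carbon. Among the compounds with values here, one measured step bears on this, a 50-fold higher number from compound 2 to compound 3 (1.70 log units; beyond the scatter), where dimethylamino took the place of methoxy on an aromatic carbon. Compound 4 loses that dimethylamino group. Compound 1 carries the same 5-chloro-1H-indol-3-yl and gives 1000 nM. Within the data shown here, no measured step changes this group directly, so the inference is indirect. A large step toward a lower number is therefore expected in this assay, estimated as a 50-fold lower number from compound 3 to compound 4 (1.70 log units; beyond the scatter). For compound 4 the expected value is 1000 nM, with an estimated range of 200 nM to 5000 nM.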

Compound 4, concentration for 50% growth inhibition: 10000 nM
Estimate against measurement, compound 4: 10-fold (1.00 log units) below; measured number above the stated range.
By their numbers in this assay, from the lowest: compounds 1 and 2 (each within the scatter of the next); then compound 4; then compound 3.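

In this assay the change at this place gives a 5.0-fold lower number from compound 3 to compound 4 (0.70 log units; beyond the scatter) and so wins back only part of the loss seen with dimethylamino, while the comparison with 4-methoxyphenyl gives a 10-fold higher number from compound 2 to compound 4 (1.00 log units; beyond the scatter) among the sulfonyl compounds. With 5-chloro-1H-indol-3-yl held fixed, (4-methylphenyl)sulfonyl in place of (4-methylphenyl)sulfanyl gives a 10-fold higher number from compound 1 to compound 4 (1.00 log units; beyond the scatter) so the number of compound 1 does not carry over to the sulfonyl compound. Nothing measured here explains these steps. Left open is whether the chlorine of 5-chloro-1H-indol-3-yl contributes, and whether a hydroxyl or a primary amine in place of methoxy would keep the number of compound 2.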